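Swapping the ether for a plain propyl chain

The source may report more compounds than this note shows. Statements on the series, on what has been measured and on what is new or still open speak of the compounds shown alone.

Of the compounds shown here, two have been measured in an assay on Ltk cells with metabotropic glutamate receptor 5 (Homo sapiens) as the target, read by fluorescence and calcium flux; on this read-out higher numbers stand for weaker inhibition and lower numbers for stronger inhibition. Compound 1 `CCCOc1cccnc1Nc1cccc(C)n1` gives 1600 nM, and compound 2 `Cc1cccc(Nc2ncccc2OC(C)C)n1` gives 1000 nM. Compound 2 holds the lower of the two numbers, but the step of a 1.6-fold lower number from compound 1 to compound 2 (0.20 log units; within the scatter) is small, so the two compounds cannot be told apart on these data.

Compound 3 `CCCc1cccnc1Nc1cccc(C)n1` is the next compound, not yet measured. It differs from compound 2 in one place: propyl in place of isopropoxy on an aromatic carbon. Within the data shown here, the only measured step, from compound 1 to compound 2, kept the oxygen and changed only the shape of the carbon chain on it, so it speaks only loosely to a change that removes the oxygen altogether and leaves a bare propyl chain. Among the measured compounds shown here, no measured step shows what that removal does.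

On that basis the expectation is a step of a 1.5-fold higher number from compound 2 to compound 3 (0.18 log units; within the scatter) that stays within the scatter, in no firm direction. Compound 3 is therefore expected to give about 1500 nM in this assay, with a range from 500 nM to 5000 nM.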

Compound 3, half-maximal inhibitory concentration: 394 nM
Estimate against measurement, compound 3: 3.8-fold (0.58 log units) above, and the stated range ends above it.
By their numbers in this assay, from the lowest: compound 3; then compounds 2 and 1 (each within the scatter of the next).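

Taking the oxygen out matters at this position, unlike the change in chain shape on it. In this assay the step of a 4.1-fold lower number from compound 1 to compound 3 (0.61 log units; beyond the scatter) keeps the three-carbon chain and removes only the oxygen, yet it lies beyond the scatter, as does the step of a 2.5-fold lower number from compound 2 to compound 3 (0.40 log units; beyond the scatter). By contrast, the step of a 1.6-fold lower number from compound 1 to compound 2 (0.20 log units; within the scatter), which only reshapes the chain and keeps the oxygen, stays within the scatter, and no measurement here accounts for the difference.

Still open, from the compounds shown here alone, is whether a shorter chain such as ethyl, a longer chain such as butyl, or an amine linking the chain to the ring would hold or lower the number reached with propyl. It is also unknown whether branching matters once the oxygen is gone, as an isopropyl group placed directly on the aromatic carbon would show.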